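This account rests on a few compounds, and the source may have more. Where it says the series, first, only, none or still open, it means among the compounds named here.

Compound 1 `Cc1cc(O)cc(-c2nn(CC#N)cc2-c2ccnc(-c3ccc(Oc4ccccc4)cc3)c2)c1` gives 6840 nM in a functional assay on MDA-MB-435 cells (Homo sapiens) for inhibition, read by sulforhodamine B assay, with a stated time of 48 h; a lower number here means a stronger inhibitor of growth, a higher number a weaker inhibitor of growth.
Compound 2 `COc1cc(C)cc(-c2nn(CC#N)cc2-c2ccnc(-c3ccc(N(C)C)cc3)c2)c1` gives 613 nM in this assay.

Of these two, compound 2 gives the lower number, and the gap to compound 1 lies beyond the usual scatter. Compound 3 `Cc1cc(O)cc(-c2nn(CC#N)cc2-c2ccnc(-c3ccc(N(C)C)cc3)c2)c1` has not yet been measured; it differs from compound 2 by hydrogen in place of methyl on an oxygen on an aromatic ring. Among the compounds with values here, no measured pair isolates that change, so its direction in this assay cannot be read from the data; a small step, not clearly beyond the scatter, is expected. Compound 3 is expected to give about 900 nM, between 300 nM and 3000 nM. This estimate means a step of a 1.5-fold higher number from compound 2 to compound 3 (0.17 log units; within the scatter).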

Compound 3, concentration for total growth inhibition: 3210 nM
Compound 3: middle estimate off by 3.6-fold (0.55 log units), on the low side; the measured number lies above the stated range.
By their numbers in this assay, from the lowest: compound 2; then compound 3; then compound 1.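

On the oxygen of the 3-methoxy-5-methylphenyl group, the methyl matters: hydrogen in its place gives a 5.2-fold higher number from compound 2 to compound 3 (0.72 log units; beyond the scatter) in this assay, so methoxy to hydroxy is no silent swap here. With the hydroxy kept, dimethylamino in place of phenoxy gives a 2.1-fold lower number from compound 1 to compound 3 (0.33 log units; beyond the scatter), a step that shows the other end of the molecule also moves the number. Nothing available explains either step.

On these data alone, whether an ethyl group on this oxygen, or an amine in place of the hydroxy, would match compound 2 remains open. So does whether the phenoxy to dimethylamino step would keep its size with methoxy in place of hydroxy.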